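Replacing the Trihydroxyphenyl Group of Compound 1

A few compounds are considered here, and "the series" means these few. Any claim that something is new, unique, unknown or untested is made for them only; others in the source may bear on it.

Three related compounds have been measured so far. In a functional assay on DU-145 cells (Homo sapiens) for inhibition, read by trypan blue exclusion, with a stated time of 96 h (on this read-out higher numbers stand for weaker inhibition of growth and lower numbers for stronger inhibition of growth), compound 1 (`Cc1ccc(CS/C(=C/c2ccc(O)c(O)c2O)C(=O)c2ccc(Cl)cc2)cc1`) gives 50000 nM as the highest of the three numbers, which makes it the weakest growth inhibitor among them. Compound 2 (`O=C(/C(=C\c1ccc([N+](=O)[O-])c(O)c1)SCc1ccc(Br)cc1)c1ccc(Br)cc1`) gives 10000 nM and compound 3 (`COc1cc(C(=O)/C(=C\c2ccc([N+](=O)[O-])c(O)c2)SCc2ccc(Br)cc2)cc(OC)c1OC`) gives 1000 nM in this assay and both sit lower than compound 1 by more than the usual scatter of repeat measurements.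

The next compound, compound 4 (`Cc1ccc(CS/C(=C/c2c[nH]c3ccc(Cl)cc23)C(=O)c2ccc(Cl)cc2)cc1`), keeps the rest of compound 1 and alters one group: 5-chloro-1H-indol-3-yl in place of 2,3,4-trihydroxyphenyl on a double-bonded chain carbon bound to a double-bonded chain carbon. In words, 5-chloro-1H-indol-3-yl stands in place of 2,3,4-trihydroxyphenyl on a double-bonded chain carbon bound to a double-bonded chain carbon.

Going by the values given here, no two measured compounds differ in only one place, so nothing shows directly how large such a change can be. Compound 1 at 50000 nM lies at the top of the measured numbers and compound 3 at 1000 nM lies at the bottom, so a moderate move toward stronger inhibition is expected in this assay rather than a further rise. The expected size of this move is a 10-fold lower number from compound 1 to compound 4 (1.00 log units; beyond the scatter) as an estimate with wide uncertainty. The estimated value for compound 4 is 5000 nM with an expected range from 500 nM to 50000 nM.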

Compound 4, concentration for 50% growth inhibition: 1000 nM
Beside the measured number, compound 4's estimate is 5.0-fold (0.70 log units) above it; measured number inside the range.
By their numbers in this assay, from the lowest: compounds 3 and 4 (each within the scatter of the next); then compound 2; then compound 1.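

In this assay, going by these compounds alone, putting 5-chloro-1H-indol-3-yl in place of 2,3,4-trihydroxyphenyl gives a 50-fold lower number from compound 1 to compound 4 (1.70 log units; beyond the scatter) and is the first single change that can be read directly. It shows that this place, on a double-bonded chain carbon bound to a double-bonded chain carbon, has a large effect on the number while the rest of the structure stays the same, and that growth inhibition here does not depend on keeping the 2,3,4-trihydroxyphenyl group. No measurement shown explains why the number falls so far.

This one step changes several things together, since the three hydroxyl groups leave while a five-membered aromatic ring with its nitrogen and a chlorine enter, so it cannot say which of these parts accounts for the stronger inhibition. As far as these compounds go, whether the plain 1H-indol-3-yl group without its chlorine, or a phenyl ring with a single hydroxyl group, would give a similar number remains open.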